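The source may hold more compounds than are shown below. What is called first, only, known or untested is meant among the compounds shown, and "the series" means these compounds.

Three compounds have numbers in a physicochemical assay for lipophilicity, using the shake flask method, at pH 7.4; a higher number here means a more lipophilic compound, a lower number a more polar compound. Compound 1 `CC(=O)N1CCN([C@H]2CC[C@H](Nc3ncnn4ccc([C@H]5CC[C@H](C(N)=O)CC5)c34)CC2)CC1` gives 1.4, compound 3 `CN(C)[C@H]1CC[C@H](Nc2ncnc3cscc23)CC1` gives 0.3, and compound 2 `CC(=O)N1CCN([C@H]2CC[C@H](Nc3ncnn4ccc(C(C)C)c34)CC2)CC1` gives 2.4, the highest of the three and beyond the scatter of both others. Compound 4 `CC(=O)N1CCN([C@H]2CC[C@H](Nc3ncnn4ccc(C5CCOCC5)c34)CC2)CC1` has no number yet. It differs from compound 2 in one place, with oxan-4-yl in place of isopropyl on an aromatic carbon.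

Going by the values given here, only one measured step involves a change of this group. Putting isopropyl in place of 4-carbamoylcyclohexyl on an aromatic carbon gave a number 1.00 log units higher from compound 1 to compound 2 (beyond the scatter). Compound 4 goes the opposite way, leaving isopropyl for a ring-bearing group, although oxan-4-yl is not the group found in compound 1. On the evidence of that single step, a fall in this assay is expected, probably smaller than the rise seen there. The expected change is a number 0.70 log units lower from compound 2 to compound 4 (beyond the scatter). The estimate for compound 4 is 1.7, with an expected range from 1.3 to 2.1.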

Compound 4, distribution coefficient: 1.6
The estimate for compound 4 lay 0.10 log units above the measured number, within the range that was stated.
By their numbers in this assay, from the lowest: compound 3; then compounds 1 and 4 (each within the scatter of the next); then compound 2.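

Putting oxan-4-yl in place of isopropyl on this aromatic carbon gives a number 0.80 log units lower from compound 2 to compound 4 (beyond the scatter) in this assay and so shows that the number at this position can fall without a carbamoyl group. Oxan-4-yl in place of 4-carbamoylcyclohexyl gives a number 0.20 log units higher from compound 1 to compound 4 (within the scatter) and leaves compound 1 and compound 4 indistinguishable in this assay despite their different groups. Nothing available explains either step.

The compounds shown leave open whether the fall from compound 2 goes with the added ring or with its oxygen, and plain cyclohexyl, which has carbon in place of that oxygen, would separate the two. Piperidin-4-yl, which has an amine nitrogen there, would show how a different ring atom reads at this position.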